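Swapping the Amine Tail for a Hydroxy Group

This account rests on a few compounds, and the source may have more. Where it says the series, first, only, none or still open, it means among the compounds named here.

Compound 1 `CCN(CC)CCCNC(=O)c1ccc(C(CC)(CC)c2ccc(C#CC(O)(CC)CC)c(C)c2)n1CC` is the only one of the three measured compounds with an actual number: in a functional assay on MCF7 cells (Homo sapiens) for antiproliferative activity, read by MTT assay, with a stated time of 72 h (a lower number here means a stronger inhibitor, a higher number a weaker inhibitor), compound 1 gives 17800 nM. Compound 2 `CCn1c(C(=O)NCc2ccc(OC)cc2)ccc1C(CC)(CC)c1ccc(C#CC(O)(CC)CC)c(C)c1` reaches only a limit of the assay, > 50000 nM. Compound 3 `CCCCC(=O)c1ccc(C(CC)(CC)c2ccc(C#CC(O)(CC)CC)c(C)c2)n1CC` likewise reaches only a limit, > 50000 nM. Compound 4 `CCn1c(C(=O)NCCCO)ccc1C(CC)(CC)c1ccc(C#CC(O)(CC)CC)c(C)c1` differs from compound 1 in one place: hydroxy in place of diethylamino on a saturated chain carbon, three bonds along the chain from an amide-type nitrogen. Both measured steps that alter the amide side bear on this change: an at least 2.8-fold higher number from compound 1 to compound 2 (0.44 log units; beyond the scatter) and an at least 2.8-fold higher number from compound 1 to compound 3 (0.44 log units; beyond the scatter), each ending at the limit of > 50000 nM in this assay, at which 2 of the 3 values shown sit. Taking the diethylamino group away is therefore expected to weaken inhibition as well, and the expected step is a 2.2-fold higher number from compound 1 to compound 4 (0.35 log units; beyond the scatter). The estimate for compound 4 is 40000 nM, with a range from 15000 nM to 110000 nM.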

Compound 4, half-maximal inhibitory concentration: 5950 nM
The estimate for compound 4 lay 6.7-fold (0.83 log units) above the measured number; measured number below the stated range.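

The diethylamino group is not needed for activity on this chain, since putting hydroxy in its place makes the compound more potent, not less (a 3.0-fold lower number from compound 1 to compound 4 (0.48 log units; beyond the scatter)). The 3-hydroxypropyl amide also clearly outperforms the butyl ketone (an at least 8.4-fold lower number from compound 3 to compound 4 (0.92 log units; beyond the scatter)) and the 4-methoxybenzyl amide (an at least 8.4-fold lower number from compound 2 to compound 4 (0.92 log units; beyond the scatter)). Both of these steps start from a limit, not a number: (the limit of > 50000 nM in this assay, at which 2 of the 4 values shown sit). Still open, going by these compounds, is whether hydroxy itself matters or any small group would do at this chain end. A primary amine, a carboxylic acid or a longer chain carrying the hydroxy would begin to settle that.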